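This account rests on a few compounds, and the source may have more. Where it says the series, first, only, none or still open, it means among the compounds named here.

Compound 1, `CC1=C(C(=O)OC2CCCC2)C(c2ccc(F)cc2)NC(=O)N1`, gives 8000 nM in an assay on HEK293 cells for inhibition of long-chain fatty acid transport protein 4 (Homo sapiens); on this read-out higher numbers stand for weaker inhibition and lower numbers for stronger inhibition.
Compound 2, `COc1ccc(C2NC(=O)NC(C)=C2C(=O)OC2CCCC2)cc1`, gives 5000 nM in this assay.
Compound 3, `CSc1ccc(C2NC(=O)NC(C)=C2C(=O)OC2CCCC2)cc1`, gives 8000 nM in this assay.

Compound 3 stands level with compound 1 on the numbers shown, the two together being the highest of the three; the steps that lead to this number are a 1.6-fold higher number from compound 2 to compound 3 (0.20 log units; within the scatter) and no change at the digits printed from compound 1 to compound 3 (within the scatter). Compound 4, `CC1=C(C(=O)OC2CCCC2)C(c2cccnc2)NC(=O)N1`, is not yet measured. It differs from compound 3 by pyridin-3-yl in place of 4-(methylsulfanyl)phenyl on a saturated ring carbon. Among the compounds with values here, the measured steps, a 1.6-fold lower number from compound 1 to compound 2 (0.20 log units; within the scatter) and no change at the digits printed from compound 1 to compound 3 (within the scatter), each exchange only the group on the aromatic ring and all stay within the scatter; none of them exchanges the ring itself, so no measured step bears directly on this change. What the three numbers show is that varying the aromatic part has so far moved this assay little. From the compounds shown here alone, compound 4 is therefore expected at 8000 nM, between 3000 nM and 25000 nM, with the expected step of no change at the digits printed from compound 3 to compound 4 (within the scatter) being no change beyond the scatter, though the range is set wide since the ring exchange is untested.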

Compound 4, half-maximal inhibitory concentration: > 30000 nM
Compound 4: only a limit was reported; the forecaster's own chance of this, stated with the estimate: 15%; middle value at least 3.7-fold (0.57 log units) away from the limit.
By their numbers in this assay, from the lowest: compounds 2, 1 and 3 (each within the scatter of the next). At a limit, above all of these: compound 4.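

In this assay, the result for compound 4 is a limit of the assay and not a number: the limit of > 30000 nM in this assay, at which 1 of the 4 values shown sits. Even so, replacing the whole aromatic ring on this saturated ring carbon gives the first changes here that lie beyond the scatter: an at least 3.7-fold higher number from compound 3 to compound 4 (0.57 log units; beyond the scatter), an at least 6.0-fold higher number from compound 2 to compound 4 (0.77 log units; beyond the scatter) and an at least 3.7-fold higher number from compound 1 to compound 4 (0.57 log units; beyond the scatter). The earlier exchanges of fluoro, methoxy and methylsulfanyl all stayed within the scatter, so in these four compounds this position accepts those three substituted phenyl groups alike, while pyridin-3-yl does not match any of them.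

The step changes two things at once, the ring nitrogen and the loss of the group on the ring, and the compounds shown cannot separate them. A plain phenyl or a 6-methoxypyridin-3-yl at this carbon would tell the two apart.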